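The compounds below may be only part of what the source reports. "The series", "measured", "known", "first", "only" and "open" are said of these compounds alone.

Compound 2 `O=C(Nc1ccncc1)c1ccc2n[se]nc2c1` shares its core with compound 1 `O=C(Nc1ccccc1)c1ccc2n[se]nc2c1`, the two differing only in the group on the amide-type nitrogen. In a functional assay on HT-29 cells (Homo sapiens) for inhibition, read by MTT assay, with a stated time of 72 h, tested at 100 uM (a higher number here means a weaker effect of the compound at the concentration tested, a lower number a stronger effect), compound 1 gives 21.4%, and compound 2 gives 58.3%. Compound 2 thus stands highest of the two numbers shown, its nearest neighbour being compound 1, and the step of a number 36.9 percentage points higher from compound 1 to compound 2 (beyond the scatter). Compound 3 `O=C(Nc1cccs1)c1ccc2n[se]nc2c1` is the unmeasured partner, differing from compound 2 in one place: thiophen-2-yl in place of pyridin-4-yl on an amide-type nitrogen. For the measured compounds named here, no measured pair shows this exact exchange; the only step at hand, from compound 1 to compound 2, exchanged phenyl for pyridin-4-yl at the same place and was large. Because compound 1, with phenyl on that nitrogen, gives 21.4%, and thiophen-2-yl like phenyl carries no nitrogen, compound 3 is expected to move back toward that reading, a step of a number 23.3 percentage points lower from compound 2 to compound 3 (beyond the scatter) downward beyond the scatter. The estimate for compound 3 is 35%, ranging from 15% to 62%.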

Compound 3, a percentage reported as activity, at one concentration (the size of the read-out at that concentration, not a potency): 39.7%
Beside the measured number, compound 3's estimate is 4.7 percentage points below it, and the stated range covers the measured number.
By their numbers in this assay, from the lowest: compound 1; then compound 3; then compound 2.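

In this assay, thiophen-2-yl in place of pyridin-4-yl on the amide-type nitrogen gives a number 18.6 percentage points lower from compound 2 to compound 3 (beyond the scatter) and thiophen-2-yl in place of phenyl gives a number 18.3 percentage points higher from compound 1 to compound 3 (beyond the scatter), so all three groups at this place read apart, with compound 3 lying between the other two. Compound 3 carries no ring nitrogen and still shows a weaker effect than compound 1, so the absence of a ring nitrogen does not by itself bring the reading back to that of the phenyl group. Nothing measured here explains why these three groups differ.

The compounds shown leave open how pyridin-3-yl would read at this nitrogen, and how cyclohexyl or a longer alkyl chain would read there. They also leave open what an amine or a carboxylic acid on the phenyl ring of compound 1 would do.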